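From Cyano to Trifluoromethyl on an Aromatic Carbon

This account rests on a few compounds, and the source may have more. Where it says the series, first, only, none or still open, it means among the compounds named here.

In a functional assay on MCF7 cells (Homo sapiens) for antiproliferative activity, read by CellTiter-Glo, with a stated time of 5 days (on this read-out higher numbers stand for weaker inhibition and lower numbers for stronger inhibition), compound 1 (`O=C(O)/C=C/c1ccc(/C(=C(\c2ccc(C(F)(F)F)cc2Cl)C2CCC2)c2ccc3scnc3c2)cc1`) gives 2.6 nM and compound 2 (`N#Cc1ccc(/C(=C(\c2ccc(/C=C/C(=O)O)cc2)c2ccc(-c3cn[nH]c3)cc2)C2CCC2)c(Cl)c1`) gives 2.2 nM, so the two numbers lie within the scatter of each other. Compound 3 (`O=C(O)/C=C/c1ccc(/C(=C(\c2ccc(C(F)(F)F)cc2Cl)C2CCC2)c2ccc(-c3cn[nH]c3)cc2)cc1`) has trifluoromethyl in place of cyano on an aromatic carbon. For the measured compounds named here, no measured pair shows this change, but the 2-chloro-4-(trifluoromethyl)phenyl group also occurs in compound 1, at 2.6 nM. No shift beyond the scatter is therefore expected in this assay, and the expected step is a 1.1-fold higher number from compound 2 to compound 3 (0.06 log units; within the scatter). For compound 3 the estimate is 2.5 nM, with an expected range of 0.9 nM to 7 nM.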

Compound 3, half-maximal inhibitory concentration: 16 nM
Beside the measured number, compound 3's estimate is 6.4-fold (0.81 log units) below it, and the stated range ends below it.
By their numbers in this assay, from the lowest: compounds 2 and 1 (each within the scatter of the next); then compound 3.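

In this assay, this position does not take the change freely: trifluoromethyl in place of cyano gives a 7.3-fold higher number from compound 2 to compound 3 (0.86 log units; beyond the scatter). With trifluoromethyl held fixed, 4-(1H-pyrazol-4-yl)phenyl in place of 1,3-benzothiazol-5-yl gives a 6.2-fold higher number from compound 1 to compound 3 (0.79 log units; beyond the scatter), so the 2-chloro-4-(trifluoromethyl)phenyl group does not bring a low number with it in every compound shown. No supporting measurement here bears on the reason for either step.

The compounds shown leave open whether cyano would give a similar number alongside 1,3-benzothiazol-5-yl. They also leave open how a methyl group or an amide would fare at this position.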